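A few compounds are considered here, and "the series" means these few. Any claim that something is new, unique, unknown or untested is made for them only; others in the source may bear on it.

Measured so far:
compound 1 `Cn1c(=O)c(S(=O)(=O)c2ccc(Cl)cc2Cl)cc2cnc(Nc3ccc4[nH]ccc4c3)nc21`: 1000 nM
compound 2 `CN1CCN(c2ccc(Nc3ncc4cc(S(=O)(=O)c5ccc(F)cc5F)c(=O)n(C)c4n3)cc2)CC1`: 5000 nM

In a functional assay on K562 cells (Homo sapiens) for inhibition, read by trypan blue exclusion, with a stated time of 72 h (a higher number here means a weaker inhibitor, a lower number a stronger inhibitor), compound 1 gives 1000 nM, the lowest of the two numbers. Among the measured compounds shown here, compound 2 gives 5000 nM, a gap beyond the scatter, but the two structures differ in more than one place and no single step is computed for that pair. Compound 3 `Cc1ccc(S(=O)(=O)c2cc3cnc(Nc4ccc5[nH]ccc5c4)nc3n(C)c2=O)cc1` is not yet measured. Its difference from compound 1: 4-methylphenyl in place of 2,4-dichlorophenyl on a sulfonyl sulfur. For the measured compounds named here, no measured step covers this change, so only a small step is expected, none beyond the scatter or a slight lean toward a higher number. Compound 3 is expected at 1500 nM, range 600 nM to 4000 nM. The expected step is a 1.5-fold higher number from compound 1 to compound 3 (0.18 log units; within the scatter).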

Compound 3, half-maximal inhibitory concentration: 750 nM
Compound 3: middle estimate off by 2.0-fold (0.30 log units), on the high side; the measured number falls inside the stated range.
By their numbers in this assay, from the lowest: compounds 3 and 1 (each within the scatter of the next); then compound 2.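

In this assay, among the compounds shown here, the exchange of 2,4-dichlorophenyl for 4-methylphenyl on the sulfonyl sulfur gives a 1.3-fold lower number from compound 1 to compound 3 (0.12 log units; within the scatter) and is the first single-place step. At this place, the loss of both chlorine atoms together with the entry of a methyl group leaves the number within the scatter, so the two groups cannot be told apart here. Nothing at hand bears on the reason for this result.

The separate contributions of the chlorine atoms and the methyl group remain unresolved. Also open, going by these compounds, is whether a carboxylic acid or a primary amine on this phenyl ring, or a cyclohexyl group in its place, would move the number beyond the scatter.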